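The source may report more compounds than this note shows. Statements on the series, on what has been measured and on what is new or still open speak of the compounds shown alone.

Measured so far in a functional assay on AN3-CA cells (Homo sapiens) for antiproliferative activity, read by MTT assay, with a stated time of 72 h; on this read-out higher numbers stand for weaker inhibition and lower numbers for stronger inhibition:
compound 1 `O=C(Nc1ccc(Cl)c(-c2nnc3c(Cl)cccn23)c1)c1ccccc1` gives 67600 nM
compound 2 `O=C(Nc1ccc(Cl)c(-c2nnc3c(Cl)cccn23)c1)c1c(F)cccc1Cl` gives only the limit > 100000 nM
compound 3 `CS(=O)(=O)c1ccc(C(=O)Nc2ccc(Cl)c(-c3nnc4c(Cl)cccn34)c2)cc1` gives only the limit > 100000 nM

For the measured compounds named here, compound 1 thus holds the only actual number; the other two values are limits of this assay. Compound 4 `O=C(Nc1ccc(Cl)c(-c2nnc3c(Cl)cccn23)c1)c1ccc(F)cc1Cl` differs from compound 1 by 2-chloro-4-fluorophenyl in place of phenyl on a carbonyl carbon. The closest measured step is an at least 1.4-fold higher number from compound 1 to compound 2 (0.17 log units; that floor lies within the scatter), which also altered the phenyl on the carbonyl carbon; that step and an at least 1.4-fold higher number from compound 1 to compound 3 (0.17 log units; that floor lies within the scatter) both ran into (the limit of > 100000 nM in this assay, at which 2 of the 3 values shown sit). For compound 4 a weaker result is therefore expected, most likely again a limit rather than a number. Compound 4 is estimated at 120000 nM, within 40000 nM to 300000 nM. That corresponds to an expected step of a 1.8-fold higher number from compound 1 to compound 4 (0.25 log units; within the scatter).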

Compound 4, half-maximal inhibitory concentration: > 100000 nM
Compound 4: only a limit was reported; the forecaster's own chance of this, stated with the estimate: 65%; the middle value is on the limit's open side.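

In this assay, 2-chloro-4-fluorophenyl in place of phenyl on the carbonyl carbon gives an at least 1.4-fold higher number from compound 1 to compound 4 (0.17 log units; that floor lies within the scatter), so a second chlorine-and-fluorine ring, after the 2-chloro-6-fluorophenyl of compound 2, also yields no actual number. Compounds 2, 3 and 4 all carry limits, so the steps among them cannot be read. Compound 1 remains the only measured number, and the true size of this change stays hidden: the limit of > 100000 nM in this assay, at which 3 of the 4 values shown sit.

Going by these compounds, whether any group here inhibits more strongly than the phenyl of compound 1 stays open. A phenyl carrying an amine or a carboxylic acid could test this.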